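A few compounds are considered here, and "the series" means these few. Any claim that something is new, unique, unknown or untested is made for them only; others in the source may bear on it.

Compound 1 `CN(C)c1ccc(C=C2C(=O)N(c3ccc(Cl)cc3)N(c3ccc(Cl)cc3)C2=O)cc1` carries a 4-(dimethylamino)phenyl group on a double-bonded chain carbon bound to a double-bonded ring carbon of the shared core. In a functional assay on ECa-109 cells (Homo sapiens) for cytotoxicity, read by MTT assay, with a stated time of 72 h (a lower number here means a stronger inhibitor, a higher number a weaker inhibitor), compound 1 gives only a limit of the assay, > 128000 nM, and no number, which places it at the weak end of the three measured values (the limit of > 128000 nM in this assay, at which 1 of the 3 values shown sits). Compound 2 `O=C1C(=Cc2ccc(Br)cc2)C(=O)N(c2ccc(Cl)cc2)N1c1ccc(Cl)cc1` reaches 12300 nM in this assay, and compound 3 `COc1cc(C=C2C(=O)N(c3ccc(Cl)cc3)N(c3ccc(Cl)cc3)C2=O)ccc1O` reaches 7100 nM. The step of an at least 10-fold lower number from compound 1 to compound 2 (1.01 log units; beyond the scatter) is large, as is an at least 18-fold lower number from compound 1 to compound 3 (1.25 log units; beyond the scatter), while a 1.7-fold lower number from compound 2 to compound 3 (0.24 log units; within the scatter) lies within the scatter. Compound 4 `O=C1C(=Cc2cccc(Cl)c2)C(=O)N(c2ccc(Cl)cc2)N1c1ccc(Cl)cc1` has not yet been measured; it differs from compound 1 in one place: 3-chlorophenyl in place of 4-(dimethylamino)phenyl on a double-bonded chain carbon bound to a double-bonded ring carbon. The change trades the dimethylamino-bearing ring for a chloro-bearing ring, closest in kind to the measured step of an at least 10-fold lower number from compound 1 to compound 2 (1.01 log units; beyond the scatter), where a bromo took the place of dimethylamino on an aromatic carbon. A large step toward a lower number is therefore expected, an at least 10-fold lower number from compound 1 to compound 4 (1.02 log units; beyond the scatter). Compound 4 is estimated to give 12000 nM in this assay, within a range from 4000 nM to 40000 nM.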

Compound 4, half-maximal inhibitory concentration: 22600 nM
For compound 4 the middle estimate is 1.9-fold (0.27 log units) below the measured one; the measured number falls inside the stated range.
By their numbers in this assay, from the lowest: compounds 3, 2 and 4 (each within the scatter of the next, the first and the last beyond it). At a limit, above all of these: compound 1.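

Replacing the 4-(dimethylamino)phenyl group with a 3-chlorophenyl group also gives a clear gain (an at least 5.6-fold lower number from compound 1 to compound 4 (0.75 log units; beyond the scatter)), so a second halogen-bearing ring at this place lies well clear of compound 1. From the compounds shown here alone, the true size of that step stays unknown because compound 1 gives a limit and not a number: the limit of > 128000 nM in this assay, at which 1 of the 4 values shown sits. Among the compounds with real numbers, 3-chlorophenyl and 4-bromophenyl cannot be told apart (a 1.8-fold higher number from compound 2 to compound 4 (0.26 log units; within the scatter)), but this place now shows its first step beyond the scatter between such compounds (a 3.2-fold higher number from compound 3 to compound 4 (0.50 log units; beyond the scatter)).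

Going by these compounds, what a 4-chlorophenyl or a 3-bromophenyl group would give stays open, so the effects of the halogen and its ring position cannot yet be separated. Also open, on these data alone, is how a ring bearing a primary amine or a carboxylic acid would read in this assay.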